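The source may hold more compounds than are shown below. What is called first, only, known or untested is meant among the compounds shown, and "the series" means these compounds.

Measured compounds:
compound 1 `Cc1c(-c2csc(/N=C3\S/C(=C\c4ccc(N(C)C)cc4)C(=O)N3c3ccccc3)n2)c(=O)n(-c2ccccc2)n1C` – > 100000 nM
compound 2 `COc1ccc(/C=C2\S/C(=N\c3nc(-c4c(C)n(C)n(-c5ccccc5)c4=O)cs3)N(c3ccccc3)C2=O)cc1` – 26100 nM

For the measured compounds named here, in a functional assay on MCF7 cells (Homo sapiens) for cytotoxicity, read by sulforhodamine B assay, with a stated time of 72 h (a higher number here means a weaker inhibitor, a lower number a stronger inhibitor), compound 2 gives 26100 nM, the only true number among the two results. Compound 1 gives a limit, > 100000 nM, in this assay. The step of an at least 3.8-fold lower number from compound 1 to compound 2 (0.58 log units; beyond the scatter) is therefore known only as a bound, resting on (the limit of > 100000 nM in this assay, at which 1 of the 2 values shown sits). Compound 3 `Cc1c(-c2csc(/N=C3\S/C(=C\c4ccco4)C(=O)N3c3ccccc3)n2)c(=O)n(-c2ccccc2)n1C` differs from compound 2 by furan-2-yl in place of 4-methoxyphenyl on a double-bonded chain carbon bound to a double-bonded ring carbon. Going by the values given here, no measured step touches that position, so the single measured step gives no direct guide. The step of a 1.3-fold higher number from compound 2 to compound 3 (0.13 log units; within the scatter) is expected to fall within the usual scatter. Compound 3 is estimated at 35000 nM, with a range from 10000 nM to 120000 nM.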

Compound 3, half-maximal inhibitory concentration: 22400 nM
Estimate against measurement, compound 3: 1.6-fold (0.19 log units) above; measured number inside the range.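

In this assay, the position on the double-bonded chain carbon bound to a double-bonded ring carbon does not distinguish furan-2-yl from 4-methoxyphenyl, with a 1.2-fold lower number from compound 2 to compound 3 (0.07 log units; within the scatter). A five-membered aromatic ring with 1 hetero atom therefore serves here as well as the six-membered one. The step of an at least 4.4-fold lower number from compound 1 to compound 3 (0.64 log units; beyond the scatter) is known only as a bound, resting on a limit: the limit of > 100000 nM in this assay, at which 1 of the 3 values shown sits.

From the compounds shown here alone, it remains open whether an unsubstituted phenyl or a 4-carboxyphenyl at this position would match compound 2 and compound 3. Going by these compounds, it also remains open whether a saturated ring such as piperidine would.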